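Methoxy to Methyl on the Anilino Ring

A few compounds are considered here, and "the series" means these few. Any claim that something is new, unique, unknown or untested is made for them only; others in the source may bear on it.

The series is read in a functional assay on ECa-109 cells (Homo sapiens) for inhibition, read by MTT assay, with a stated time of 72 h; on this read-out lower numbers stand for stronger inhibition and higher numbers for weaker inhibition. For the measured compounds named here, compound 1 `COc1ccc(Nc2nc(SCc3cn(Cc4ccccc4Cl)nn3)nc(-c3ccccc3)c2C#N)cc1` gives 7960 nM, the only numeric value so far in this assay. Compound 2 `Cc1ccc(Cn2cc(CSc3nc(Nc4ccccc4F)c(C#N)c(-c4ccccc4)n3)nn2)cc1` gives > 64000 nM, which is a limit of this assay and not a number. Of the two values shown, (the limit of > 64000 nM in this assay, at which 1 of the 2 values shown sits). Compound 3 `Cc1ccc(Nc2nc(SCc3cn(Cc4ccccc4Cl)nn3)nc(-c3ccccc3)c2C#N)cc1` is not yet measured; it differs from compound 1 by methyl in place of methoxy on an aromatic carbon. Going by the values given here, no step between measured compounds is available, so the change is expected to shift this assay by no more than the usual scatter, if anything slightly weaker. Compound 3 is estimated at 10000 nM, between 3000 nM and 35000 nM, a step of a 1.3-fold higher number from compound 1 to compound 3 (0.10 log units; within the scatter).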

Compound 3, half-maximal inhibitory concentration: > 64000 nM
Compound 3 was reported as a limit; the forecaster's own chance of this, stated with the estimate: 15%; middle value at least 6.4-fold (0.80 log units) away from the limit.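

Methyl in place of methoxy on the anilino ring gives an at least 8.0-fold higher number from compound 1 to compound 3 (0.90 log units; beyond the scatter), the first step read at this position in this assay. Compound 3 is reported only as a limit of the assay, so the step has a floor but no measured size: the limit of > 64000 nM in this assay, at which 2 of the 3 values shown sit. Among the compounds shown, the 4-methoxyphenyl group of compound 1 is thus the only one at this position with a numeric value.

The compounds shown leave open whether hydroxy, ethoxy or dimethylamino at this place would also give a numeric value.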